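The source may report more compounds than this note shows. Statements on the series, on what has been measured and on what is new or still open speak of the compounds shown alone.

Measured so far in a functional assay on MCF7 cells (Homo sapiens) for cytotoxicity, read by neutral red uptake, with a stated time of 3 days; on this read-out lower numbers stand for stronger inhibition and higher numbers for weaker inhibition:

compound 1, `Nc1ccc(-c2cc(=O)c3c(N)c(F)cc(F)c3o2)cc1F`: 40 nM
compound 2, `Nc1ccc(-c2cc(=O)c3c(N)c(F)c(CO)c(F)c3o2)cc1F`: 62 nM
compound 3, `CN(C)c1c(F)c(N)c2c(=O)cc(-c3ccc(N)c(F)c3)oc2c1F`: 39 nM

Compound 3 gives the lowest of the three numbers in this assay, yet the steps of a 1.0-fold lower number from compound 1 to compound 3 (0.01 log units; within the scatter) and a 1.6-fold lower number from compound 2 to compound 3 (0.20 log units; within the scatter) are both within the scatter, so the three compounds cannot be told apart on these data.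

Compound 4 is `CCCOCc1c(F)c(N)c2c(=O)cc(-c3ccc(N)c(F)c3)oc2c1F`. Its change from compound 3 is propoxymethyl in place of dimethylamino on an aromatic carbon. Among the compounds with values here, the steps that bear on this position are a 1.0-fold lower number from compound 1 to compound 3 (0.01 log units; within the scatter), a 1.6-fold higher number from compound 1 to compound 2 (0.19 log units; within the scatter) and a 1.6-fold lower number from compound 2 to compound 3 (0.20 log units; within the scatter): hydrogen, hydroxymethyl and dimethylamino at this carbon all give numbers within the scatter of one another. Within the data shown here, no measured step introduces a propoxymethyl group or any chain of comparable length, so the expectation rests only on the flatness seen at this position so far.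

Compound 4 is therefore expected near 50 nM, with a range of 20 nM to 130 nM. The estimated step of a 1.3-fold higher number from compound 3 to compound 4 (0.11 log units; within the scatter) is expected to stay within the scatter, in no clear direction.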

Compound 4, half-maximal inhibitory concentration: 1200 nM
Compound 4: middle estimate off by 24-fold (1.38 log units), on the low side; measured number outside the range, above it.
By their numbers in this assay, from the lowest: compounds 3, 1 and 2 (each within the scatter of the next); then compound 4.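

In this assay this aromatic carbon is no longer flat once propoxymethyl sits on it: hydrogen gives way to propoxymethyl with a 30-fold higher number from compound 1 to compound 4 (1.48 log units; beyond the scatter) and dimethylamino gives way to it with a 31-fold higher number from compound 3 to compound 4 (1.49 log units; beyond the scatter) as the second large step. The closest pair is the most telling, since propyl in place of hydrogen on the oxygen of hydroxymethyl gives a 19-fold higher number from compound 2 to compound 4 (1.29 log units; beyond the scatter) and so places the weakening with that propyl on the oxygen, not with substitution at this carbon as such. No measurement shown accounts for this step.

The compounds shown leave open whether the weakening sets in gradually along the chain, as methoxymethyl and ethoxymethyl would show. They also leave open whether the ether oxygen matters, which a plain butyl chain at this carbon would test.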